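Swapping 2,3-dichlorophenyl for 4-methoxyphenyl

The source may report more compounds than this note shows. Statements on the series, on what has been measured and on what is new or still open speak of the compounds shown alone.

In a functional assay on A549 cells (Homo sapiens) for antiproliferative activity, read by MTT assay (on this read-out higher numbers stand for weaker inhibition and lower numbers for stronger inhibition), compound 1 `Cn1c(=O)c(=O)n(C2CCCC2)c2nc(N/N=C/c3ccc(S(C)(=O)=O)cc3)ncc21` gives 84500 nM, compound 2 `COc1cccc(/C=N/Nc2ncc3c(n2)n(C2CCCC2)c(=O)c(=O)n3C)c1` gives 27400 nM and compound 3 `Cn1c(=O)c(=O)n(C2CCCC2)c2nc(N/N=C/c3cccc(Cl)c3Cl)ncc21` gives 39100 nM. Compound 3 thus stands close to compound 2 and clearly apart from compound 1. Compound 4 `COc1ccc(/C=N/Nc2ncc3c(n2)n(C2CCCC2)c(=O)c(=O)n3C)cc1` has 4-methoxyphenyl in place of 2,3-dichlorophenyl on a carbon with a double bond to nitrogen. Leaving 4-(methylsulfonyl)phenyl brought modest steps, a 3.1-fold lower number from compound 1 to compound 2 (0.49 log units; beyond the scatter) and a 2.2-fold lower number from compound 1 to compound 3 (0.33 log units; beyond the scatter). Within the data shown here, the closest precedent, exchanging 3-methoxyphenyl for 2,3-dichlorophenyl, gave only a 1.4-fold higher number from compound 2 to compound 3 (0.15 log units; within the scatter). No change beyond the scatter is therefore expected in this assay, and the estimated step is a 1.3-fold lower number from compound 3 to compound 4 (0.12 log units; within the scatter). Compound 4 is expected at about 30000 nM, within a range of 12000 nM to 75000 nM.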

Compound 4, half-maximal inhibitory concentration: > 100000 nM
Compound 4: no number, only a limit (the forecaster's own chance of this, stated with the estimate: 10%); at least 3.3-fold (0.52 log units) between middle value and limit.
By their numbers in this assay, from the lowest: compounds 2 and 3 (each within the scatter of the next); then compound 1. At a limit, above all of these: compound 4.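

Compound 4 gives a limit of the assay, not a number: the limit of > 100000 nM in this assay, at which 1 of the 4 values shown sits. Even so, where the methoxy group sits on the phenyl ring matters at this position, with an at least 3.6-fold higher number from compound 2 to compound 4 (0.56 log units; beyond the scatter), and replacing 2,3-dichlorophenyl gives an at least 2.5-fold higher number from compound 3 to compound 4 (0.40 log units; beyond the scatter), whereas 3-methoxyphenyl and 2,3-dichlorophenyl stood within the scatter of each other. Against 4-(methylsulfonyl)phenyl no order can be set, with an at least 1.1-fold higher number from compound 1 to compound 4 (0.07 log units; that floor lies within the scatter).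

The data do not show what sets 4-methoxyphenyl apart from 3-methoxyphenyl. They also do not show whether a 4-aminophenyl group or a 4-carboxyphenyl group would behave like 4-methoxyphenyl.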